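This account rests on a few compounds, and the source may have more. Where it says the series, first, only, none or still open, it means among the compounds named here.

Compound 1 `Cc1cc(N[C@H](CCCCNCc2cccc(F)c2)C(=O)NO)cc(C)c1F`, compound 2 `Cc1ccc(CNCCCC[C@@H](Nc2cc(C)c(F)c(C)c2)C(=O)NO)cc1` and compound 3 `Cc1cc(N[C@H](CCCCNCc2ccc(C(C)(C)C)cc2)C(=O)NO)cc(C)c1F` share one core and differ only in the group on a saturated chain carbon bound to an amine nitrogen, with the tert-butyl in place of methyl change being one example. In a physicochemical assay for solubility, in phosphate buffer (a higher number here means a more soluble compound, a lower number a less soluble compound), compound 1 reads > 5 ug/mL and that is a limit, not a number. Compound 2 reads > 5 ug/mL and that too is a limit. Compound 3 stands at > 5 ug/mL and this is also only a limit.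

Compound 4 `Cc1cc(N[C@H](CCCCNCCCc2ccc(F)cc2)C(=O)NO)cc(C)c1F` differs from compound 3 in one place: 2-(4-fluorophenyl)ethyl in place of 4-(tert-butyl)phenyl on a saturated chain carbon bound to an amine nitrogen with 2-(4-fluorophenyl)ethyl in place of 4-(tert-butyl)phenyl on a saturated chain carbon bound to an amine nitrogen.

The measured changes that bear on this are a step that the two limits leave unreadable from compound 1 to compound 2 and a step that the two limits leave unreadable from compound 1 to compound 3 and also a step that the two limits leave unreadable from compound 2 to compound 3 in the same series. All the evidence is the limit of > 5 ug/mL in this assay, at which 3 of the 3 values shown sit, and so none of these steps has a size to carry forward. No direction can be drawn, and the expected change is a step that the limit leaves unreadable from compound 3 to compound 4 with nothing beyond the usual scatter foreseen. For compound 4 the estimated solubility is 15 ug/mL with an expected range from 5 ug/mL to 60 ug/mL and this expectation may well end in a limit again.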

Compound 4, solubility: > 5 ug/mL
Compound 4: no number, only a limit; the forecaster's own chance of this, stated with the estimate: 75%; the middle value is on the limit's open side.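

Compound 4 reads > 5 ug/mL and that is a limit, not a number. The steps linking compound 4 with compound 1, compound 2 and compound 3 therefore cannot be read: the limit of > 5 ug/mL in this assay, at which 4 of the 4 values shown sit. The compounds shown leave open how far their actual solubilities differ, if at all, in this assay when the group on the saturated chain carbon bound to an amine nitrogen changes.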